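Swapping an Amide Aryl Group in a Pancreatic Cell Assay

The compounds below may be only part of what the source reports. "The series", "measured", "known", "first", "only" and "open" are said of these compounds alone.

Compound 1, `CC(C)=CCC/C(C)=C/CC1Cc2c(OCC=C(C)C)cc(=O)n(CCCO)c2CC1(C)C`, gives 15.9% in a functional assay on PANC-1 cells (Homo sapiens) for inhibition, read by MTT assay, with a stated time of 24 h, tested at 10 uM; a higher number here means more inhibition at the concentration tested (going by the name of the read-out), a lower number less inhibition.
Compound 2, `COc1ccc(C(=O)NCCCOc2cc(=O)n(CCCO)c3c2CC(C/C=C(\C)CCC=C(C)C)C(C)(C)C3)cc1`, gives 14.1% in this assay.

Within the data shown here, compound 2 stands at the lower of the two numbers measured so far, but its gap to compound 1 is within the scatter of repeated measurements, so the two compounds cannot be told apart on these data. Compound 3, `CC(C)=CCC/C(C)=C/CC1Cc2c(OCCCNC(=O)c3ccco3)cc(=O)n(CCCO)c2CC1(C)C`, differs from compound 2 in a single place: furan-2-yl in place of 4-methoxyphenyl on a carbonyl carbon. Among the measured compounds shown here, no pair of measured compounds differing in one place is available, so there is no measured step to lean on for this change. For the measured compounds named here, with only two compounds that agree within the scatter, the step from compound 2 to compound 3 in this assay is expected to be none beyond the scatter, namely a number 0.1 percentage points lower from compound 2 to compound 3 (within the scatter). Compound 3 is therefore estimated at 14%, with a range from 4% to 26%.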

Compound 3, a percentage reported as inhibition, at one concentration (the size of the read-out at that concentration, not a potency): 2.8%
The estimate for compound 3 lay 11.2 percentage points above the measured number; measured number below the stated range.
By their numbers in this assay, from the lowest: compound 3; then compounds 2 and 1 (each within the scatter of the next).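

Furan-2-yl in place of 4-methoxyphenyl on the amide carbonyl gives a number 11.3 percentage points lower from compound 2 to compound 3 (beyond the scatter) in this assay and so shows that the group at this place can change the read-out, which the two earlier compounds could not show. Compound 3 also falls clearly short of compound 1, with a number 13.1 percentage points lower from compound 1 to compound 3 (beyond the scatter) for the swap of 2-methylprop-1-en-1-yl for 2-(((furan-2-yl)carbonyl)amino)ethyl on a saturated chain carbon bound to an oxygen on an aromatic ring. Nothing at hand explains why the furan-2-yl amide reads lower.

A single swap cannot say whether the difference comes from bringing in the furan-2-yl ring or from losing the 4-methoxyphenyl group. A plain phenyl or a thiophen-2-yl ring on the same carbonyl would help to separate those two readings.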